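The source may hold more compounds than are shown below. What is called first, only, known or untested is meant among the compounds shown, and "the series" means these compounds.

Measured so far in a functional assay on CHO cells for agonist activity at metabotropic glutamate receptor 2 (Homo sapiens), read by GTPgammaS binding; a higher number here means a larger maximal response, a lower number a smaller maximal response:
compound 1 `CCCn1ccc2cc(-c3cccnc3)cc(Cl)c2c1=O`, 83%
compound 2 `CCCn1ccc2cc(-c3ccc(OC)nc3)cc(Cl)c2c1=O`, 121%
compound 3 `CCCn1ccc2cc(-c3ccc(OCCc4ccccc4)nc3)cc(Cl)c2c1=O`, 103%

Compound 3 stands second highest of the three numbers. Its nearest neighbour is compound 2, the step of a number 18 percentage points lower from compound 2 to compound 3 (beyond the scatter) lying beyond the scatter, and the step of a number 20 percentage points higher from compound 1 to compound 3 (beyond the scatter) sets it furthest from compound 1, also beyond the scatter. Compound 4 `CCCn1ccc2cc(-c3ccc(OCc4cccnc4)nc3)cc(Cl)c2c1=O` is next; it differs from compound 3 by pyridin-3-yl in place of benzyl on a saturated chain carbon bound to an oxygen on an aromatic ring. Among the compounds with values here, none of the measured steps exchanges one aromatic ring for another on the saturated chain carbon bound to an oxygen on an aromatic ring. Within the data shown here, the two steps in the same part of the molecule, a number 38 percentage points higher from compound 1 to compound 2 (beyond the scatter) and a number 18 percentage points lower from compound 2 to compound 3 (beyond the scatter), concern whole groups entering in place of hydrogen and shift the maximal response by large to modest amounts; an exchange of a ring of carbon only for a ring with one hetero atom, the chain otherwise kept, has no precedent here. The maximal response of compound 4 is therefore expected close to that of compound 3, with a step of a number 2 percentage points higher from compound 3 to compound 4 (within the scatter) that is expected to stay within the scatter. The estimate for compound 4 in this assay is 105%, between 85% and 125%.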

Compound 4, largest response reached (Emax), in percent of the reference or control that the assay uses: 120%
Estimate against measurement, compound 4: 15 percentage points below, within the range that was stated.
By their numbers in this assay, from the lowest: compound 1; then compound 3; then compounds 4 and 2 (each within the scatter of the next).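

In this assay, pyridin-3-yl in place of benzyl on the saturated chain carbon bound to an oxygen on an aromatic ring gives a number 17 percentage points higher from compound 3 to compound 4 (beyond the scatter), so this position responds to an exchange between groups as well as to a group entering in place of hydrogen. The size of the group alone does not set the response: the step from the small methoxy to (pyridin-3-yl)methoxy is a number 1 percentage points lower from compound 2 to compound 4 (within the scatter), and the step from hydrogen to (pyridin-3-yl)methoxy is a number 37 percentage points higher from compound 1 to compound 4 (beyond the scatter), while compound 3 stays apart from both. No measurement at hand bears on why the maximal response moves with this exchange.

The step from phenethyloxy to (pyridin-3-yl)methoxy changes the ring and the chain together, and these compounds cannot separate the two. As far as these compounds go, how an amine or a carboxylic acid on the same saturated chain carbon would read remains open.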